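This account rests on a few compounds, and the source may have more. Where it says the series, first, only, none or still open, it means among the compounds named here.

Working notes on the series. Compound 1 `O=C1C(O)=C(C(c2cccs2)c2c[nH]c3ccccc23)C(=O)c2ccccc21` has no phenyl on the five-membered aromatic ring with one nitrogen; in a functional assay on HeLa cells (Homo sapiens) for cytotoxicity, read by MTT assay, with a stated time of 48 h (a lower number here means a stronger inhibitor, a higher number a weaker inhibitor), compound 1 gives 12400 nM. Compound 2 `O=C1C(O)=C(C(c2cccc([N+](=O)[O-])c2)c2c(-c3ccccc3)[nH]c3ccccc23)C(=O)c2ccccc21` carries a phenyl on that ring, next to the ring nitrogen, and differs from compound 1 at its other variable group as well; in this assay compound 2 gives 12500 nM. Among the compounds with values here, compound 2 holds the highest of the two numbers so far, yet its nearest neighbour, compound 1, sits within the scatter of it, so the two values cannot be separated. Compound 3 `O=C1C(O)=C(C(c2cccc([N+](=O)[O-])c2)c2c[nH]c3ccccc23)C(=O)c2ccccc21` is the next member to be measured in this assay. The change from compound 2 to compound 3 is hydrogen in place of phenyl on an aromatic carbon. Within the data shown here, no measured pair isolates this change, so there is no ground for a step beyond the scatter in either direction. Among the measured compounds shown here, the only comparison available, compound 1 against compound 2, shows the values of a phenyl-bearing and a phenyl-free member lying together. Compound 3 is therefore expected to give 12000 nM, within 5000 nM to 30000 nM, an expected step of a 1.0-fold lower number from compound 2 to compound 3 (0.02 log units; within the scatter) of no real size.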

Compound 3, half-maximal inhibitory concentration: 24900 nM
Estimate against measurement, compound 3: 2.1-fold (0.32 log units) below, and the stated range covers the measured number.
By their numbers in this assay, from the lowest: compounds 1, 2 and 3 (each within the scatter of the next).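

In this assay, the pair that isolates the phenyl on the aromatic carbon of the five-membered aromatic ring gives a 2.0-fold higher number from compound 2 to compound 3 (0.30 log units; within the scatter) and so does not separate hydrogen from phenyl at this position. The pair that isolates the other variable group gives a 2.0-fold higher number from compound 1 to compound 3 (0.30 log units; within the scatter) and likewise does not separate 3-nitrophenyl from thiophen-2-yl on the saturated chain carbon. Within the data shown here, each change can now be read on its own, which compounds 1 and 2 alone did not allow, although no evidence on the compounds bears on these results.

Open, as far as these compounds go, is whether a group other than phenyl on this aromatic carbon, such as an amine or a methyl, would give a step beyond the scatter, and the same holds for a phenyl carrying a carboxylic acid in place of 3-nitrophenyl on the chain carbon. Also open, from the compounds shown here alone, is whether either change would stay within the scatter on a core carrying the other group, since each has been read on one background only.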